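Chloro to trifluoromethyl on the phenyl ring of the core

The compounds below may be only part of what the source reports. "The series", "measured", "known", "first", "only" and "open" are said of these compounds alone.

Three measured compounds share one core. Compound 1 `CC(=O)Nc1cccc(C2CCN(CCn3c(-c4ccccc4)nc4ccccc43)CC2)c1`, with the shorter chain to the core, gives 10000 nM in an assay for displacement of a labelled ligand from melanin-concentrating hormone receptor 1 (Homo sapiens), read by fluorescence; on this read-out higher numbers stand for weaker inhibition and lower numbers for stronger inhibition. Compound 2 `CC(=O)Nc1cccc(C2CCN(CCCn3c(-c4ccccc4)nc4ccccc43)CC2)c1`, with the longer chain, gives 2 nM in this assay. For the measured compounds named here, compound 3 `CC(=O)Nc1cccc(C2CCN(CCCn3c(-c4cccc(Cl)c4)nc4ccccc43)CC2)c1` carries a chloro group and gives 5 nM in this assay; the step of a 2.5-fold higher number from compound 2 to compound 3 (0.40 log units; beyond the scatter) is the only one-place step available. Compound 3 thus stands second highest of the three numbers, nearest compound 2 and far removed from compound 1.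

Compound 4 `CC(=O)Nc1cccc(C2CCN(CCCn3c(-c4cccc(C(F)(F)F)c4)nc4ccccc43)CC2)c1` differs from compound 3 in one place: trifluoromethyl in place of chloro on an aromatic carbon. Going by the values given here, no measured pair covers chloro to trifluoromethyl; the only step at this aromatic carbon is a 2.5-fold higher number from compound 2 to compound 3 (0.40 log units; beyond the scatter), a modest one. On that basis the expected step of a 1.6-fold higher number from compound 3 to compound 4 (0.20 log units; within the scatter) in this assay is small, from none beyond the scatter to a modest move toward a higher number. Compound 4 is accordingly estimated at 8 nM, with a range from 3 nM to 25 nM.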

Compound 4, half-maximal inhibitory concentration: 30 nM
Beside the measured number, compound 4's estimate is 3.8-fold (0.57 log units) below it; the measured number lies above the stated range.
By their numbers in this assay, from the lowest: compound 2; then compound 3; then compound 4; then compound 1.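

In this assay this aromatic carbon proves less tolerant than the chloro compound alone suggested: trifluoromethyl in place of chloro gives a 6.0-fold higher number from compound 3 to compound 4 (0.78 log units; beyond the scatter) and is beyond the scatter. Measured against the unsubstituted phenyl, the change gives a 15-fold higher number from compound 2 to compound 4 (1.18 log units; beyond the scatter) and is a large loss, so substitution here is no longer a modest matter. Across compound 2, compound 3 and compound 4, the number rises from hydrogen through chloro to trifluoromethyl, an order that rests on these three compounds only.

On these data alone, whether fluoro, methyl or methoxy at this carbon would fall into the same order remains open. Also open, as far as these compounds go, is whether trifluoromethyl on another carbon of this phenyl ring, or with a four-carbon chain, would give a similar step. No available measurement explains the order of these three compounds.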